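This account rests on a few compounds, and the source may have more. Where it says the series, first, only, none or still open, it means among the compounds named here.

Three relatives sharing one core have been tested in a functional assay on HL-60 cells (Homo sapiens) for antiproliferative activity, read by MTT assay, with a stated time of 48 h; a higher number here means a weaker inhibitor, a lower number a stronger inhibitor. Compound 1 (`COC/C1=C/C[C@](C)(CCC=C(C)C)/C=C/[C@@H](OC(=O)C=C(C)C)[C@](C)(OC)/C=C/C1=O`) gives 4050 nM, and compound 2 (`CO[C@]1(C)/C=C/C(=O)/C(CO)=C\C[C@](C)(CCC=C(C)C)/C=C/[C@H]1OC(=O)C=C(C)C`) gives 14300 nM. Compound 3 (`CC(C)=CCC[C@]1(C)/C=C/[C@@H](OC(=O)C=C(C)C)[C@](C)(O)/C=C/C(=O)/C(C(=O)O)=C\C1`) gives > 10000 nM, which is a limit of the assay and not a number. Compound 3 therefore has no exact place on the scale.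

Compound 4 (`CC(C)=CCC[C@]1(C)/C=C/[C@@H](OC(=O)C=C(C)C)[C@](C)(O)/C=C/C(=O)/C(CN(C(C)C)C(C)C)=C\C1`) keeps the core of compound 3 and changes one group on a double-bonded ring carbon: (diisopropylamino)methyl in place of carboxy, ((diisopropylamino)methyl in place of carboxy on a double-bonded ring carbon). For the measured compounds named here, only one measured step touches the group on that ring carbon. Hydrogen in place of methyl on an oxygen gives a 3.5-fold higher number from compound 1 to compound 2 (0.55 log units; beyond the scatter), a modest step from a much smaller swap, so it guides only loosely.

The expectation rests mainly on compound 1 at 4050 nM and compound 2 at 14300 nM, which lack the carboxy and still give real numbers, although both also carry a methoxy group where compound 3 has a hydroxy group. In this assay the expected change is an at least 2.8-fold lower number from compound 3 to compound 4 (0.45 log units; beyond the scatter), towards a stronger inhibitor. From the compounds shown here alone, its true size stays open, as the starting point is only a limit. The estimate for compound 4 is 3500 nM, with an expected range from 1000 nM to 10000 nM.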

Compound 4, half-maximal inhibitory concentration: 740 nM
For compound 4 the middle estimate is 4.7-fold (0.67 log units) above the measured one; the whole stated range lies above it.
By their numbers in this assay, from the lowest: compound 4; then compound 1; then compound 2.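

Swapping carboxy for (diisopropylamino)methyl on the double-bonded ring carbon gives, in this assay, an at least 13-fold lower number from compound 3 to compound 4 (1.13 log units; beyond the scatter), a large move towards a stronger inhibitor. For the compounds shown here, this is the first direct view of what a change of group at this ring carbon can do: the position can carry a group of 8 heavy atoms, with one nitrogen and no oxygen, and compound 4 still gives a real number on the scale, 740 nM. The step itself is only a lower bound on the true change, since compound 3 stands at a limit of the assay and not at a number: the limit of > 10000 nM in this assay, at which 1 of the 4 values shown sits.

Because the whole group changes in one move, the compounds shown cannot separate the loss of carboxy from the arrival of the amine, or the role of the nitrogen from that of its two isopropyl groups. A smaller amine such as (dimethylamino)methyl, a ring amine such as piperidin-1-ylmethyl, or a methyl ester in place of the carboxy would each help to tell these apart.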